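The source may report more compounds than this note shows. Statements on the series, on what has been measured and on what is new or still open speak of the compounds shown alone.

Measured so far in a functional assay on CFPAC-1 cells (Homo sapiens) for antiproliferative activity, read by MTT assay, with a stated time of 72 h; a lower number here means a stronger inhibitor, a higher number a weaker inhibitor:
- compound 1 `CCCCCc1ccc(-c2cn(C[C@H](O)[C@H]3OC(=O)C(OCc4ccccc4)=C3OCc3ccccc3)nn2)cc1` gives 9890 nM
- compound 2 `O=C1O[C@H]([C@@H](O)Cn2cc(CNS(=O)(=O)c3ccc(Cl)cc3)nn2)C(OCc2ccccc2)=C1OCc1ccccc1` gives 38900 nM
- compound 3 `O=C1O[C@H]([C@@H](O)Cn2ccnn2)C(OCc2ccccc2)=C1OCc1ccccc1` gives only a limit, > 100000 nM

Compound 3 therefore stands at the weak end of the three: its value is a limit of the assay, not a number, and the limit of > 100000 nM in this assay, at which 1 of the 3 values shown sits, marks where it sits. The two measured steps that lead to it both remove a substituent from an aromatic carbon of the shared core: an at least 10-fold higher number from compound 1 to compound 3 (1.00 log units; beyond the scatter) and an at least 2.5-fold higher number from compound 2 to compound 3 (0.41 log units; beyond the scatter). Both are beyond the scatter and point the same way, a substituent on that carbon giving the lower number.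

Compound 4 `CCCCc1cn(C[C@H](O)[C@H]2OC(=O)C(OCc3ccccc3)=C2OCc2ccccc2)nn1` has not been measured in this assay. Its change from compound 3 is butyl in place of hydrogen on an aromatic carbon. Butyl is a smaller group than either 4-pentylphenyl or (((4-chlorophenyl)sulfonyl)amino)methyl, so the step is expected to run in the direction of compound 1 and compound 2 but not to reach the full size of an at least 10-fold higher number from compound 1 to compound 3 (1.00 log units; beyond the scatter). The estimated step is an at least 2.5-fold lower number from compound 3 to compound 4 (0.39 log units; beyond the scatter), a lower number than the limit of compound 3 but with a real chance that the assay again reports only a limit. Compound 4 is thus expected at 40000 nM, within 15000 nM to 110000 nM.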

Compound 4, half-maximal inhibitory concentration: 73200 nM
For compound 4 the middle estimate is 1.8-fold (0.26 log units) below the measured one, within the range that was stated.
By their numbers in this assay, from the lowest: compound 1; then compounds 2 and 4 (each within the scatter of the next). At a limit, above all of these: compound 3.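

In this assay compound 3 remains a limit of the assay and not a number: the limit of > 100000 nM in this assay, at which 1 of the 4 values shown sits.

Butyl on this aromatic carbon gives an at least 1.3-fold lower number from compound 3 to compound 4 (0.13 log units; that floor lies within the scatter), so a plain alkyl chain in place of hydrogen cannot yet be told apart from hydrogen itself, a point the earlier steps, with their larger groups, did not raise. Set against the other substituents, butyl shows no separation from the ((4-chlorophenyl)sulfonyl)amino side chain, with a 1.9-fold higher number from compound 2 to compound 4 (0.27 log units; within the scatter), whereas 4-pentylphenyl stays clearly ahead, with a 7.4-fold higher number from compound 1 to compound 4 (0.87 log units; beyond the scatter), so among the substituents shown only compound 1 stands apart at this position.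

Whether the aryl ring or the pentyl chain accounts for the lower number of compound 1 stays open, and an unsubstituted phenyl or a longer chain such as octyl on the same carbon would separate the two. Also open, as far as these compounds go, is how this carbon responds to a group of another kind, such as an aminomethyl or a carboxylic acid.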